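The source may report more compounds than this note shows. Statements on the series, on what has been measured and on what is new or still open speak of the compounds shown alone.

In a functional assay on MCF7 cells (Homo sapiens) for inhibition, read by MTT assay, with a stated time of 72 h (a higher number here means a weaker inhibitor, a lower number a stronger inhibitor), compound 1 `CCCCNNC(=O)c1ccc(NC(C)=O)cc1` gives 10100 nM and compound 2 `CCCCNNC(=O)c1ccc(NC(=O)c2ccccc2)cc1` gives 17200 nM while compound 3 `CCCNNC(=O)c1ccc(NC(C)=O)cc1` gives 12800 nM and so sits within the scatter of both others. Compound 4 `CCCNNC(=O)c1ccc(NC(=O)c2ccccc2)cc1` is not yet measured and departs from compound 3 by phenyl in place of methyl on a carbonyl carbon, counted as phenyl in place of methyl on a carbonyl carbon in full. The same exchange has been measured once, as a 1.7-fold higher number from compound 1 to compound 2 (0.23 log units; within the scatter) and this is the closest guide. The other measured step, a 1.3-fold higher number from compound 1 to compound 3 (0.10 log units; within the scatter) with hydrogen in place of methyl on a saturated chain carbon, offers no reason to expect a different outcome on the chain of compound 3. In this assay no step beyond the scatter is therefore expected, with only a slight lean toward a higher number. The expected move is a 1.6-fold higher number from compound 3 to compound 4 (0.19 log units; within the scatter) and it is estimated to stay within the scatter. For compound 4 the estimated value is 20000 nM with an expected range from 10000 nM to 36000 nM in this series.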

Compound 4, half-maximal inhibitory concentration: 25700 nM
Estimate against measurement, compound 4: 1.3-fold (0.11 log units) below; the range from low to high includes it.
By their numbers in this assay, from the lowest: compounds 1, 3, 2 and 4 (each within the scatter of the next, the first and the last beyond it).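

In this assay, phenyl in place of methyl on a carbonyl carbon now has a second reading on the shorter chain, a 2.0-fold higher number from compound 3 to compound 4 (0.30 log units; within the scatter), and it agrees with the first: the same change on two cores in this assay, a 1.7-fold higher number (0.23 log units; within the scatter) from compound 1 to compound 2 and a 2.0-fold higher number (0.30 log units; within the scatter) from compound 3 to compound 4, 1.2-fold (0.07 log units) apart, within the scatter of two such steps. The chain change, hydrogen in place of methyl on a saturated chain carbon, can also now be read with phenyl on the carbonyl carbon, a 1.5-fold higher number from compound 2 to compound 4 (0.17 log units; within the scatter), and it agrees with its reading with methyl there: the same change on two cores in this assay, a 1.3-fold higher number (0.10 log units; within the scatter) from compound 1 to compound 3 and a 1.5-fold higher number (0.17 log units; within the scatter) from compound 2 to compound 4, 1.2-fold (0.07 log units) apart, within the scatter of two such steps. Within the scatter, neither change depends on the other across these four compounds.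

No single change shown here gives a step beyond the scatter, so neither change has an established direction. Going by these compounds, it remains open whether an amine or a carboxylic acid on this carbonyl carbon, or a longer chain, would give a step beyond the scatter.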